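Trifluoromethyl to methoxy: expectation for compound 4

The source may report more compounds than this note shows. Statements on the series, on what has been measured and on what is new or still open speak of the compounds shown alone.

In a functional assay on A549 cells (Homo sapiens) for antiproliferative activity, read by MTT assay, with a stated time of 48 h (a lower number here means a stronger inhibitor, a higher number a weaker inhibitor), compound 1 (`Cc1ccc(-c2nnc(NC(=O)/C=C/c3ccc(C(F)(F)F)cc3)s2)cc1`) gives 1.61 ug/mL, compound 2 (`O=C(/C=C/c1ccc(C(F)(F)F)cc1)Nc1nnc(-c2ccc(Br)cc2)s1`) gives 4.68 ug/mL and compound 3 (`O=C(/C=C/c1ccc(C(F)(F)F)cc1)Nc1nnc(-c2ccccc2)s1`) gives 1.78 ug/mL. Compound 3 matches compound 1 within the scatter (a 1.1-fold higher number from compound 1 to compound 3 (0.04 log units; within the scatter)) and stands clear of compound 2 (a 2.6-fold lower number from compound 2 to compound 3 (0.42 log units; beyond the scatter)). Compound 4 (`COc1ccc(/C=C/C(=O)Nc2nnc(-c3ccccc3)s2)cc1`) differs from compound 3 by methoxy in place of trifluoromethyl on an aromatic carbon, with methoxy in place of trifluoromethyl on an aromatic carbon. Among the compounds with values here, no measured step changes this site, so the evidence is indirect. Changes elsewhere stay small, the largest being modest (a 2.9-fold higher number from compound 1 to compound 2 (0.46 log units; beyond the scatter)). In this assay, no step beyond the scatter is therefore expected, and no firm direction. The expected step is a 1.2-fold higher number from compound 3 to compound 4 (0.09 log units; within the scatter). For compound 4 the estimated value is 2.2 ug/mL, with an expected range of 0.8 ug/mL to 6 ug/mL.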

Compound 4, half-maximal inhibitory concentration: 0.76 ug/mL
Beside the measured number, compound 4's estimate is 2.9-fold (0.46 log units) above it; the measured number lies below the stated range.
By their numbers in this assay, from the lowest: compound 4; then compounds 1 and 3 (each within the scatter of the next); then compound 2.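

Within the data shown here, the position on the ring bearing trifluoromethyl is not silent in this assay: the only change read here gives a 2.3-fold lower number from compound 3 to compound 4 (0.37 log units; beyond the scatter), beyond the scatter though modest. Until now, only changes on the other aromatic ring had been seen, so a second site in the series now moves the number. Nothing measured here accounts for this step.

From the compounds shown here alone, whether the oxygen of methoxy or the loss of trifluoromethyl drives the step stays open, and a hydroxyl or an amine at this site would bear on that. Also open, going by these compounds, is whether the step holds with methyl or bromo on the other aromatic ring.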